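Swapping fluoro for chloro: expected change in cell growth inhibition

This account rests on a few compounds, and the source may have more. Where it says the series, first, only, none or still open, it means among the compounds named here.

Three measured compounds share one core and differ only in the halogen on the phenyl ring at the end of the double-bonded chain. In a functional assay on PC-3 cells (Homo sapiens) for antiproliferative activity, read by MTT assay, with a stated time of 72 h (on this read-out lower numbers stand for stronger inhibition and higher numbers for weaker inhibition), compound 1 `O=C(COc1ccc(C(=O)/C=C/c2ccccc2Cl)cc1)N[C@H]1CCOC1=O` gives 4610 nM, compound 2 `O=C(COc1ccc(C(=O)/C=C/c2cccc(Br)c2)cc1)N[C@H]1CCOC1=O` gives 7890 nM, and compound 3 `O=C(COc1ccc(C(=O)/C=C/c2cccc(F)c2)cc1)N[C@H]1CCOC1=O` gives 23200 nM, the highest of the three numbers and therefore the weakest inhibitor here. Compound 4 `O=C(COc1ccc(C(=O)/C=C/c2cccc(Cl)c2)cc1)N[C@H]1CCOC1=O` differs from compound 3 by chloro in place of fluoro on an aromatic carbon. The step that bears most directly is a 2.9-fold higher number from compound 2 to compound 3 (0.47 log units; beyond the scatter), a modest rise when bromo gave way to fluoro; a 5.0-fold higher number from compound 1 to compound 3 (0.70 log units; beyond the scatter) points the same way. Reversing part of that, compound 4 is expected to show a 2.4-fold lower number from compound 3 to compound 4 (0.39 log units; beyond the scatter). The estimate for compound 4 is 9500 nM, with a range from 4500 nM to 20000 nM.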

Compound 4, half-maximal inhibitory concentration: 4990 nM
Estimate against measurement, compound 4: 1.9-fold (0.28 log units) above, and the stated range covers the measured number.
By their numbers in this assay, from the lowest: compounds 1, 4 and 2 (each within the scatter of the next); then compound 3.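

In this assay chloro in place of fluoro brings a 4.6-fold lower number from compound 3 to compound 4 (0.67 log units; beyond the scatter) while chloro in place of bromo gives a 1.6-fold lower number from compound 2 to compound 4 (0.20 log units; within the scatter) and so, among the three halogens at this place, only fluoro stands apart. Changing 2-chlorophenyl to 3-chlorophenyl gives a 1.1-fold higher number from compound 1 to compound 4 (0.03 log units; within the scatter) and so these two arrangements cannot be told apart here. Nothing available explains why fluoro differs. Still open, going by these compounds, is whether a methoxy group, a nitrile or a plain hydrogen at this place would side with chloro and bromo or with fluoro.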